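From acetoxy to dimethylamino in a cell growth assay

The source may report more compounds than this note shows. Statements on the series, on what has been measured and on what is new or still open speak of the compounds shown alone.

compound 1 `CC(=O)OC/C1=C/C[C@](C)(CCC=C(C)C)/C=C/[C@@H](OC(=O)C=C(C)C)[C@](C)(O)/C=C/C1=O`: 2950 nM
compound 2 `CC(=O)OC/C1=C/C[C@](C)(CCC=C(C)C)/C=C/[C@@H](OC(=O)C=C(C)C)[C@](C)(OC(C)=O)/C=C/C1=O`: 3520 nM
compound 3 `CC(=O)O[C@]1(C)/C=C/C(=O)/C(CO)=C\C[C@](C)(CCC=C(C)C)/C=C/[C@H]1OC(=O)C=C(C)C`: 2010 nM

In a functional assay on SW480 cells (Homo sapiens) for antiproliferative activity, read by MTT assay, with a stated time of 48 h (a lower number here means a stronger inhibitor, a higher number a weaker inhibitor), compound 1 gives 2950 nM, a value within the usual scatter of those of both compound 2 and compound 3. These three compounds therefore cannot be ranked on these numbers.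

The next compound, compound 4 `CC(C)=CCC[C@]1(C)/C=C/[C@@H](OC(=O)C=C(C)C)[C@](C)(O)/C=C/C(=O)/C(CN(C)C)=C\C1`, has not yet been measured. It changes compound 1 as follows: dimethylamino in place of acetoxy on a saturated chain carbon bound to a double-bonded ring carbon. In short, dimethylamino takes the place of acetoxy on a saturated chain carbon bound to a double-bonded ring carbon.

Two measured steps offer guidance. The closer one is a 1.8-fold lower number from compound 2 to compound 3 (0.24 log units; within the scatter), since it removes the acetyl from this same acetoxymethyl group. The other is a 1.2-fold higher number from compound 1 to compound 2 (0.08 log units; within the scatter), which alters a different oxygen. Both stayed within the scatter, so swapping these acetyl groups changed little. However, no measured compound carries dimethylamino, which leaves the range wide.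

No step beyond the scatter is expected, and the expected change is a 1.2-fold lower number from compound 1 to compound 4 (0.07 log units; within the scatter). For compound 4 the estimated value is 2500 nM, with an expected range of 800 nM to 7000 nM.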

Compound 4, half-maximal inhibitory concentration: 480 nM
The estimate for compound 4 lay 5.2-fold (0.72 log units) above the measured number; measured number outside the range, below it.
By their numbers in this assay, from the lowest: compound 4; then compounds 3, 1 and 2 (each within the scatter of the next).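

In this assay, among these compounds, putting dimethylamino in place of acetoxy on this saturated chain carbon gives a 6.1-fold lower number from compound 1 to compound 4 (0.79 log units; beyond the scatter), the only step in this set that lies beyond the scatter. The earlier step at this same group, which only removed the acetyl and left an oxygen in place, stayed within the scatter, so it gave no sign that this position could shift the number at all; exchanging the acetoxy for a nitrogen-bearing group shows that it can. Nothing available here explains why the number falls with this change.

From the compounds shown here alone, whether the drop belongs to dimethylamino alone or would also appear with other amines at this carbon, such as diethylamino or morpholine, stays open. Also open, going by these compounds, is whether it would persist with the other oxygen acetylated, as in compound 2.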